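The compounds below may be only part of what the source reports. "The series", "measured", "known", "first", "only" and "open" are said of these compounds alone.

Three nucleoside analogues have so far been tested in a functional assay on HepG2 cells (Homo sapiens) for antiproliferative activity, read by XTT assay, with a stated time of 72 h; on this read-out higher numbers stand for weaker inhibition and lower numbers for stronger inhibition. Compound 1, `O=c1[nH]cnc2c1c(-c1ccsc1)cn2[C@@H]1O[C@H](CO)[C@@H](O)[C@H]1O`, carries a thiophen-3-yl group on its shared core. In this assay compound 1 gives > 15000 nM, which is a limit of the assay rather than a measured number. Compound 2, `C#Cc1cn([C@@H]2O[C@H](CO)[C@@H](O)[C@H]2O)c2nc(C)nc(N)c12`, likewise reaches only a limit, > 20000 nM. Compound 3, `C#Cc1cn([C@@H]2O[C@H](CO)[C@@H](O)[C@H]2O)c2ncnc(SC)c12`, also gives a limit, > 15000 nM. Two of the three values thus sit at the limit of > 15000 nM in this assay, at which 2 of the 3 values shown sit, and one at the limit of > 20000 nM in this assay, at which 1 of the 3 values shown sits. Compound 1 therefore stands where all three stand: none of them shows measurable inhibition, and no ordering among them can be read from these numbers.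

Compound 4, `O=c1[nH]cnc2c1c(-c1ccccc1)cn2[C@@H]1O[C@H](CO)[C@@H](O)[C@H]1O`, differs from compound 1 in one place: phenyl in place of thiophen-3-yl on an aromatic carbon. Going by the values given here, no step between two measured compounds is available to show how large an effect such a change has in this assay. Because compound 1 itself gives only > 15000 nM, a limit, any small change would remain invisible. The step is expected to be a step that the limit leaves unreadable from compound 1 to compound 4, that is, nothing beyond the usual scatter. Compound 4 is therefore estimated to give 20000 nM, with a likely range from 5000 nM to 80000 nM, most probably reported again as a limit.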

Compound 4, half-maximal inhibitory concentration: > 20000 nM
Compound 4: a limit, no number (the forecaster's own chance of this, stated with the estimate: 80%); the middle value lies on the limit itself.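

Going by these compounds alone, compound 1 and compound 4 each give only a limit in this assay, not a measured number, and no step between them can be read. The compounds shown leave open how phenyl and thiophen-3-yl compare on the shared core, and which change to that core, if any, would give a measured number.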